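The source may hold more compounds than are shown below. What is called first, only, known or untested is meant among the compounds shown, and "the series" means these compounds.

Of the compounds shown here, two have so far been measured in a functional assay on NCI-H23 cells (Homo sapiens) for cytotoxicity, read by sulforhodamine B assay, with a stated time of 48 h; a higher number here means a weaker inhibitor of growth, a lower number a stronger inhibitor of growth. Compound 1 `ClCc1ccc(Cn2cnc3c(Cl)ncnc32)cc1` gives 660 nM, and compound 2 `ClCc1cccc(Cn2cnc3c(Cl)nc(Cl)nc32)c1` gives 2130 nM. Within the data shown here, of these two numbers, the one for compound 1 is the lower, and the gap between compound 1 and compound 2 is beyond the usual scatter of this assay, so compound 1 is the stronger inhibitor of growth of the pair. Compound 3 `Nc1nc(Cl)c2ncn(Cc3ccc(CCl)cc3)c2n1` has not yet been measured. It differs from compound 1 in one place: amino in place of hydrogen on an aromatic carbon. Among the measured compounds shown here, no pair of measured compounds shows what this change does in this assay, so nothing measured here points in either direction. The step expected is a 1.3-fold lower number from compound 1 to compound 3 (0.12 log units; within the scatter), which may well stay within the scatter. Compound 3 is estimated at 500 nM, expected to fall between 150 nM and 2000 nM.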

Compound 3, concentration for 50% growth inhibition: 12000 nM
The estimate for compound 3 lay 24-fold (1.38 log units) below the measured number, outside the stated range (above it).
By their numbers in this assay, from the lowest: compound 1; then compound 2; then compound 3.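

In this assay, this position on an aromatic carbon, between two ring nitrogen atoms, proves sensitive: amino in place of hydrogen gives an 18-fold higher number from compound 1 to compound 3 (1.26 log units; beyond the scatter) and so a much weaker inhibitor of growth. Among these compounds, until now, no measured pair showed what any change at this position does. This single swap of hydrogen for amino is enough to move the number well beyond the scatter, and no measurement at hand explains the size of that loss.

Among the compounds shown here, whether the loss belongs to amino itself or would follow any group placed here remains open, as only this one change at this position can be read. A methyl group, a methoxy group or a dimethylamino group in the same place would help to separate these two possibilities.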